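The compounds below may be only part of what the source reports. "The series", "measured", "known", "first", "only" and "open" are said of these compounds alone.

Compound 1, `COc1ccccc1N1CCN(CCCCC(=O)c2cccc(O)c2)CC1`: in an assay on isolated protein for binding affinity to 5-hydroxytryptamine receptor 7 (Rattus norvegicus) (on this read-out lower numbers stand for stronger inhibition and higher numbers for weaker inhibition), compound 1 gives 15 nM.
Compound 2, `CN1CCN(CCCCCC(=O)c2ccccc2O)CC1`: compound 2 reaches only a limit of the assay, > 1000 nM.

Compound 2 thus stands at the weak end of the two numbers shown, at the limit of > 1000 nM in this assay, at which 1 of the 2 values shown sits, with no firm value of its own. Compound 3, `O=C(CCCCCN1CCN(c2ccccc2)CC1)c1ccccc1O`, differs from compound 2 by phenyl in place of methyl on an amine nitrogen in a ring. Among the measured compounds shown here, no step between two measured compounds isolates this change. For the measured compounds named here, still, compound 1 carries a substituted phenyl on the same ring nitrogen and gives the only firm number here. The step is expected to be large, towards stronger binding: an at least 10-fold lower number from compound 2 to compound 3 (1.00 log units; beyond the scatter). Compound 3 is estimated at 100 nM, within 20 nM to 600 nM.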

Compound 3, inhibition constant: 43 nM
For compound 3 the middle estimate is 2.3-fold (0.37 log units) above the measured one, and the stated range covers the measured number.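

On the amine nitrogen in the ring, phenyl in place of methyl gives, in this assay, an at least 23-fold lower number from compound 2 to compound 3 (1.36 log units; beyond the scatter). Among the compounds shown here, this is the first step that isolates this one change, and it shows that a phenyl with no further substituent is enough to bring a firm number at this position. The value for compound 2 is a limit, so the step gives only its smallest size: the limit of > 1000 nM in this assay, at which 1 of the 3 values shown sits.

Going by these compounds, what a benzyl or cyclohexyl group on the same nitrogen would give stays open. So does the effect of a methoxy group on the phenyl of compound 3.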